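The source may hold more compounds than are shown below. What is called first, only, known or untested is meant among the compounds shown, and "the series" means these compounds.

For the measured compounds named here, in a functional assay on HT-29 cells (Homo sapiens) for cytotoxicity, read by MTT assay, with a stated time of 72 h (on this read-out lower numbers stand for stronger inhibition and higher numbers for weaker inhibition), compound 1 (`O=C(CN1CCN(c2nnc(Cc3ccncc3)c3ccccc23)CC1)Nc1cccc(Br)c1`) gives 1350 nM, the lowest of the three numbers so far. Compound 2 (`COc1ccc(NC(=O)CN2CCN(c3nnc(Cc4ccccc4)c4ccccc34)CC2)cc1OC`) gives 145000 nM and compound 3 (`Cc1ccccc1NC(=O)CN1CCN(c2nnc(Cc3ccccc3)c3ccccc23)CC1`) gives 113000 nM. Compound 4 (`O=C(CN1CCN(c2nnc(Cc3ccncc3)c3ccccc23)CC1)Nc1cc(C(F)(F)F)ccc1Cl`) differs from compound 1 by 2-chloro-5-(trifluoromethyl)phenyl in place of 3-bromophenyl on an amide-type nitrogen. Going by the values given here, the only measured change at this place is a 1.3-fold lower number from compound 2 to compound 3 (0.11 log units; within the scatter), which lies within the scatter. Among the compounds with values here, it comes from a pair whose remaining structure is not that of compound 1, so it is weak guidance, and no measured step starts from compound 1. No clear shift is therefore expected, with a slight lean towards a higher number. The expected step is a 1.9-fold higher number from compound 1 to compound 4 (0.27 log units; within the scatter). For compound 4 the estimate is 2500 nM, with an expected range of 500 nM to 20000 nM.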

Compound 4, half-maximal inhibitory concentration: 4810 nM
Beside the measured number, compound 4's estimate is 1.9-fold (0.28 log units) below it; measured number inside the range.
By their numbers in this assay, from the lowest: compound 1; then compound 4; then compounds 3 and 2 (each within the scatter of the next).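

At the amide-type nitrogen, 2-chloro-5-(trifluoromethyl)phenyl in place of 3-bromophenyl gives a 3.6-fold higher number from compound 1 to compound 4 (0.55 log units; beyond the scatter) on the core of compound 1. For the compounds shown here, the earlier step at this place, a 1.3-fold lower number from compound 2 to compound 3 (0.11 log units; within the scatter), stayed within the scatter on a different remainder, so this is the first change here that exceeds it, and it goes towards weaker inhibition. No available evidence explains the shift.

On these data alone, whether the chlorine or the trifluoromethyl carries the step remains open, since the two enter together. Also open, as far as these compounds go, is how a phenyl bearing an amine or a carboxylic acid would behave at this place.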